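Trimming the urea tail of a triazine sulfonylamide

A few compounds are considered here, and "the series" means these few. Any claim that something is new, unique, unknown or untested is made for them only; others in the source may bear on it.

Measured compounds:
Compound 1, `CC(C)(C)NC(=O)NCCS(=O)(=O)NC(=O)c1ccc(Nc2nc(NC3(c4ccc(Cl)cc4)CC3)nc(OCC(F)(F)F)n2)cc1`: 96%
Compound 2, `CCCCCNc1nc(Nc2ccc([N+](=O)[O-])cc2)nc(OCC(F)(F)F)n1`: 74%

Both compounds were examined in an ADME assay on microsomes from liver (Homo sapiens) for metabolic stability, with a stated time of 10 min; on this read-out lower numbers stand for a less stable compound and higher numbers for a more stable compound. Compound 1 gives 96%, the highest of the two numbers, and compound 2 gives 74%, a value that lies below that of compound 1 by more than the usual scatter. For the measured compounds named here, no pair of compounds that differ in a single place has been measured, so no measured step is available to guide the next compound.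

Compound 3, `CCS(=O)(=O)NC(=O)c1ccc(Nc2nc(NC3(c4ccc(Cl)cc4)CC3)nc(OCC(F)(F)F)n2)cc1`, has not yet been tested in this assay. It is derived from compound 1 by the change (hydrogen in place of ((tert-butyl)carbamoyl)amino on a saturated chain carbon, two bonds along the chain from a sulfonyl sulfur). Since compound 1 already sits near the top of the read-out and no comparable change has a measured step, the expectation for the step of a number 11 percentage points lower from compound 1 to compound 3 (beyond the scatter) is a modest decrease that may well remain within the scatter. Compound 3 is therefore expected to give about 85% in this assay, with a range estimated from 60% to 98%.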

Compound 3, percent of the compound remaining: 100%
For compound 3 the middle estimate is 15 percentage points below the measured one; the whole stated range lies below it.
By their numbers in this assay, from the lowest: compound 2; then compounds 1 and 3 (each within the scatter of the next).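

In this assay, for the compounds shown here, the first measured step for this change reads a number 4 percentage points higher from compound 1 to compound 3 (within the scatter), so hydrogen can stand in place of ((tert-butyl)carbamoyl)amino, on a saturated chain carbon, two bonds along the chain from a sulfonyl sulfur, with no shift beyond the scatter. Loss of this group, with its 8 heavy atoms and no ring, thus shortens the 2-(((tert-butyl)carbamoyl)amino)ethyl tail to ethyl while the read-out stays close to that of compound 1, something that the two earlier compounds, which differ in more than one place, could not show. The measurements at hand offer no explanation for this result.

On these data alone, whether the ethyl chain itself can be changed remains open, since a methyl group, a longer chain, or a chain ending in an amine or a carboxylic acid might give a different read-out in this assay. As far as these compounds go, it also remains open whether the same change would hold on another core, as this single step rests on the core of compound 1 alone.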